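The source may report more compounds than this note shows. Statements on the series, on what has been measured and on what is new or still open speak of the compounds shown alone.

Compounds measured in a functional assay on COLO 205 cells (Homo sapiens) for cytotoxicity, read by sulforhodamine B assay, with a stated time of 48 h, tested at 0.001 uM; on this read-out lower numbers stand for a stronger effect and higher numbers for a weaker effect at the one concentration tested:

Compound 1, `COc1cc(C)cc(-c2c(-c3ccnc(-c4ccc(C(C)=O)cc4)c3)cnn2CC#N)c1`, gives 109%.
Compound 2, `Cc1cc(O)cc(-c2nn(CC#N)cc2-c2ccnc(-c3ccc(Oc4ccccc4)cc3)c2)c1`, gives 107%.
Compound 3, `COc1cc(C)cc(-c2nn(CC#N)cc2-c2ccnc(-c3ccc(N(C)C)cc3)c2)c1`, gives 107%.

In this assay compound 3 stands level with compound 2 at the digits reported, and the two together hold the lowest of the three numbers. Compound 1 gives a slightly higher number than compound 3, a gap that lies within the scatter, so all three readings are indistinguishable on this read-out. Going by the values given here, no step between measured compounds that differ in a single place can be drawn from these three.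

The next compound, compound 4, is `Cc1cc(O)cc(-c2nn(CC#N)cc2-c2ccnc(-c3ccc(N(C)C)cc3)c2)c1`. Relative to compound 3 the change is hydrogen in place of methyl on an oxygen on an aromatic ring. Compound 2 already carries the hydroxy form of this group with a different partner ring, and its value in this assay sits at the same level as compound 3, which carries the methoxy. Among the compounds with values here, since every number so far falls inside one band of scatter, no step beyond the scatter is expected in this assay for this change in either direction.

Compound 4 is therefore expected to give about 107% in this assay, between 97% and 117%, an estimated step of no change at the digits printed from compound 3 to compound 4 (within the scatter).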

Compound 4, a percentage reported as activity, at one concentration (the size of the read-out at that concentration, not a potency): 109%
For compound 4 the middle estimate is 2 percentage points below the measured one; the range from low to high includes it.
By their numbers in this assay, from the lowest: compounds 2, 3, 1 and 4 (each within the scatter of the next).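

Going by these compounds alone, measured in this assay, the change from methoxy to hydroxy on the aromatic ring gives a number 2 percentage points higher from compound 3 to compound 4 (within the scatter), the first comparison in which this group alone differs, and it shows that the swap leaves the reading inside the scatter when dimethylamino is held constant. With the hydroxy form kept, dimethylamino in place of phenoxy on an aromatic carbon gives a number 2 percentage points higher from compound 2 to compound 4 (within the scatter), so this second site also shows no step beyond the scatter at the one concentration tested. No measurement at hand bears on why these readings stay together.

On these data alone, whether ethoxy or an amine in place of the hydroxy, or a carboxylic acid in place of the dimethylamino, would move the reading beyond the scatter remains open. Also open, as far as these compounds go, is whether the methoxy to hydroxy change would matter at any other concentration, since all four compounds sit in one band on this read-out and the comparisons here rest on that single tested level.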